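Fluorophenyl Placement in a Small Cytotoxic Series

This account rests on a few compounds, and the source may have more. Where it says the series, first, only, none or still open, it means among the compounds named here.

Measured so far, in a functional assay on K562 cells (Homo sapiens) for cytotoxicity, read by MTT assay, with a stated time of 24 h; on this read-out higher numbers stand for weaker inhibition and lower numbers for stronger inhibition:
Compound 1 `COc1cc(/C=C2\CN(C)C/C(=C\c3ccccc3F)C2=O)cc(OC)c1` gives 6320 nM.
Compound 2 `CN1C/C(=C\c2cccc([N+](=O)[O-])c2)C(=O)/C(=C/c2ccccc2F)C1` gives 3890 nM.
Compound 3 `COc1cc(/C=C2\CN(C)C/C(=C\c3ccc(F)cc3)C2=O)cc(OC)c1` gives 11300 nM.

Compounds 1 and 3 share one core and differ only in the fluorophenyl group: 4-fluorophenyl in place of 2-fluorophenyl on a double-bonded chain carbon bound to a double-bonded ring carbon. That change produced a 1.8-fold higher number from compound 1 to compound 3 (0.25 log units; within the scatter), so the two values are not separated by more than the usual run-to-run scatter and no order between them can be claimed.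

Compound 2 carries a different core; how it differs from the core of compound 1 is not broken down here. Its value in this assay is the lowest of the three, and the gap to compound 3 lies beyond the scatter, while the gap to compound 1 does not.

Compound 4 `CN1C/C(=C\c2ccc(F)cc2)C(=O)/C(=C/c2cccc([N+](=O)[O-])c2)C1` has not yet been measured. It stands to compound 2 exactly as compound 3 stands to compound 1: 4-fluorophenyl in place of 2-fluorophenyl on a double-bonded chain carbon bound to a double-bonded ring carbon. The place lines of the two changes read the same, so this is the same change made on the second core.

Within the data shown here, with only one earlier instance to rest on, the expectation for compound 4 is that the change behaves as it did before: a step of about a 1.8-fold higher number from compound 2 to compound 4 (0.26 log units; within the scatter) is expected, matching a 1.8-fold higher number from compound 1 to compound 3 (0.25 log units; within the scatter). Compound 4 is therefore estimated at 7000 nM, with a plausible range from 3000 nM to 16000 nM, the width reflecting that a single precedent on a different core is a thin basis.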

Compound 4, half-maximal inhibitory concentration: 11300 nM
Compound 4: middle estimate off by 1.6-fold (0.21 log units), on the low side, within the range that was stated.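

In this assay, 4-fluorophenyl in place of 2-fluorophenyl on a double-bonded chain carbon bound to a double-bonded ring carbon gives a 2.9-fold higher number from compound 2 to compound 4 (0.46 log units; beyond the scatter), so on this core the change separates the two compounds by more than the usual scatter. Set beside the earlier step, the change gives a higher number on both cores, and the sizes of the two steps cannot be told apart: the same change on two cores in this assay, a 1.8-fold higher number (0.25 log units; within the scatter) from compound 1 to compound 3 and a 2.9-fold higher number (0.46 log units; beyond the scatter) from compound 2 to compound 4, 1.6-fold (0.21 log units) apart, within the scatter of two such steps This supports carrying the change from one core to the other as a working rule for these two cores, but it does not establish a size specific to either core, since only one of the two steps lies beyond the scatter, and two cores are too few to show that the rule extends across the series or to explain the result.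

Going by these compounds, only the 2-fluorophenyl and 4-fluorophenyl groups are compared here, so it remains open whether the step would hold with an unsubstituted phenyl, a chlorophenyl, or a phenyl carrying an amine or a carboxylic acid. On these data alone, it also remains open whether a third core would give a step in the same direction, and whether the same change would behave alike in any read-out other than this assay.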